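Replacing One Group on a Compound at the Assay Limit

The source may report more compounds than this note shows. Statements on the series, on what has been measured and on what is new or still open speak of the compounds shown alone.

In a functional assay on MDA-MB-435 cells (Homo sapiens) for cytotoxicity, read by MTT assay, with a stated time of 72 h (a lower number here means a stronger inhibitor, a higher number a weaker inhibitor), compound 1 (`CS(=O)(=O)Oc1c(C(=O)NCc2ccc(F)cc2)nc(Br)c2cccnc12`) gives > 20000 nM, which is a limit and not a number. Compound 2 (`O=C(NCc1ccc(F)cc1)c1nc(NCCO)c2cccnc2c1O`) gives > 20000 nM, which is also a limit. Compound 1 therefore stands at the limit of > 20000 nM in this assay, at which 2 of the 2 values shown sit.

Compound 3 (`Nc1cccc(Nc2c(C(=O)NCc3ccc(F)cc3)nc(Br)c3cccnc23)c1`) has (3-aminophenyl)amino in place of (methylsulfonyl)oxy on an aromatic carbon. Going by the values given here, no measured step guides this change. Stronger inhibition is expected, with an estimated at least 3.3-fold lower number from compound 1 to compound 3 (0.52 log units; beyond the scatter), although the result may remain a limit. For compound 3 the expected value is 6000 nM, with an estimated range from 1000 nM to 20000 nM.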

Compound 3, half-maximal inhibitory concentration: 8000 nM
Compound 3: the middle estimate sits 1.3-fold (0.12 log units) below what was measured; measured number inside the range.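

In this assay, putting (3-aminophenyl)amino in place of (methylsulfonyl)oxy on this aromatic carbon turns a limit into a readable number, with an at least 2.5-fold lower number from compound 1 to compound 3 (0.39 log units; beyond the scatter) as the step. So this position can respond to a change of group, which the earlier compounds did not show. The size of the step remains a minimum, because compound 1 sits at a limit of the assay: the limit of > 20000 nM in this assay, at which 2 of the 3 values shown sit.

The compounds shown do not separate the effect of the aromatic ring from that of its amino group. On these data alone, how a carboxylic acid in place of that amino group would read also stays open.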